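The source may hold more compounds than are shown below. What is called first, only, known or untested is meant among the compounds shown, and "the series" means these compounds.

In a functional assay on the whole organism (strain Wistar) for inhibition, with Rattus norvegicus as the target, read by paw edema, with a stated time of 3 h, at a dose of 10 mg/kg by the oral route (a lower number here means less inhibition, a higher number more inhibition at the dose given (going by the name of the read-out)), three compounds of a shared core have numbers. Compound 1 `Clc1ccc(-c2nnc(COc3ccc(-c4ccccc4)cc3)o2)c(Cl)c1` gives 56.1%, and compound 2 `CCCCNc1nnc(COc2ccc(-c3ccccc3)cc2)o1` gives 15.9%. Within the data shown here, the one step between them, a number 40.2 percentage points lower from compound 1 to compound 2 (beyond the scatter), is the only step measured so far. Compound 3 `CCCCn1c(S)nnc1COc1ccc(-c2ccccc2)cc1` gives 75%, the highest of the three, beyond the scatter above both compound 1 and compound 2.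

Compound 4 `Sc1nnc(COc2ccc(-c3ccccc3)cc2)n1-c1ccc(Br)cc1` differs from compound 3 in one place: 4-bromophenyl in place of butyl on an aromatic nitrogen. Among the measured compounds shown here, no measured step exchanges a chain for an aromatic ring on the ring nitrogen, so nothing bears on this change directly. The step from compound 1 to compound 2, where an aromatic ring gave way to a chain on an aromatic carbon, went down by a large amount; the present change runs the other way, putting a ring where a chain was, but at a different place. Compound 4 is therefore expected to stay close to compound 3 or move somewhat, with the step of a number 7 percentage points lower from compound 3 to compound 4 (within the scatter) estimated as small. Compound 4 is estimated at 68%, with a range from 45% to 88%.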

Compound 4, a percentage reported as inhibition, in the whole organism at one dose (the size of the read-out at that dose, not a potency): 31.8%
Compound 4: middle estimate off by 36.2 percentage points, on the high side; the measured number lies below the stated range.
By their numbers in this assay, from the lowest: compound 2; then compound 4; then compound 1; then compound 3.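

On the aromatic nitrogen, this position proves sensitive to the group it carries in this assay: with 4-bromophenyl in place of butyl, the result is a number 43.2 percentage points lower from compound 3 to compound 4 (beyond the scatter). The earlier step, a number 40.2 percentage points lower from compound 1 to compound 2 (beyond the scatter), had a chain replacing an aromatic ring on an aromatic carbon and also went down, so across these two places neither a ring nor a chain gives the higher number throughout. No measurement shown here accounts for the size of this step.

The compounds shown leave open whether the lower number goes with the ring itself or with its bromine, which plain phenyl on that nitrogen would separate, and whether a shorter chain such as methyl or a longer one such as hexyl would keep the level of compound 3. They also leave open how either nitrogen substituent would fare with an amine in place of the sulfanyl group.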